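Swapping the aromatic halogen for an ethoxy group

The compounds below may be only part of what the source reports. "The series", "measured", "known", "first", "only" and "open" are said of these compounds alone.

Compound 1 `CC1(c2ccc(F)cc2)NC(=O)N(CC(O)CN2CCN(c3ccccc3F)CC2)C1=O`: 234 nM
Compound 2 `CC1(c2ccc(F)cc2)NC(=O)N(CC(O)CN2CCN(c3ccccc3Cl)CC2)C1=O`: 47 nM

In an assay on HEK293 cells for displacement of a labelled ligand from 5-hydroxytryptamine receptor 7 (Homo sapiens) (a lower number here means a stronger inhibitor, a higher number a weaker inhibitor), compound 1 gives 234 nM, and compound 2 gives 47 nM. Within the data shown here, the only change between them, chloro in place of fluoro on an aromatic carbon, produced a 5.0-fold lower number from compound 1 to compound 2 (0.70 log units; beyond the scatter). Among the measured compounds shown here, compound 2 thus holds the lowest of the two numbers measured so far.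

Compound 3 `CCOc1ccccc1N1CCN(CC(O)CN2C(=O)NC(C)(c3ccc(F)cc3)C2=O)CC1` differs from compound 2 by ethoxy in place of chloro on an aromatic carbon, on an aromatic carbon of a six-membered aromatic ring of carbon only, ortho to a large group. For the measured compounds named here, the one measured step bears on it only loosely: it shows that this position tolerates a change from fluoro to chloro with a modest gain, but no step shows an ethoxy group there. Compound 3 is therefore expected to stay near compound 2, with a 1.7-fold higher number from compound 2 to compound 3 (0.23 log units; within the scatter) as the estimated outcome. Compound 3 is estimated at 80 nM, within 25 nM to 250 nM.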

Compound 3, inhibition constant: 10 nM
Beside the measured number, compound 3's estimate is 8.0-fold (0.90 log units) above it; measured number below the stated range.
By their numbers in this assay, from the lowest: compound 3; then compound 2; then compound 1.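

In this assay, the position ortho to a large group on the aromatic ring now proves open to more than a halogen swap. Ethoxy, with its 3 heavy atoms and 1 hydrogen-bond acceptor, replaces the single chlorine atom and gives a 4.7-fold lower number from compound 2 to compound 3 (0.67 log units; beyond the scatter). Measured against fluoro, the same position gives a 23-fold lower number from compound 1 to compound 3 (1.37 log units; beyond the scatter), so among these three compounds the order runs from fluoro through chloro to ethoxy, with every step beyond the scatter. Nothing available accounts for this gain.

The compounds shown leave open whether a methoxy group or a longer propoxy chain at this position would lower the number further, and whether an amine there would match ethoxy. They also leave open whether the gain from ethoxy carries over to any other core.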